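The source may hold more compounds than are shown below. What is called first, only, known or untested is meant among the compounds shown, and "the series" means these compounds.

Values in an ADME assay on HEK-293T cells (Homo sapiens) for cytotoxicity, read by luminescence, with a stated time of 24 h (a lower number here means that less compound is tolerated, a higher number that more compound is tolerated), all limits of the assay:
- compound 1 `COc1ccc(Cn2c(C(=O)NC(C)c3ccccc3)cc3sccc32)cc1`: > 100000 nM
- compound 2 `CCCNC(=O)C1CCN(C(=O)c2cc3sc(C(=O)c4ccccc4)cc3n2Cc2ccc(OC)cc2)CC1`: > 100000 nM
- compound 3 `CCCNC(=O)C1CCN(C(=O)c2cc3sc(C(C)=O)cc3n2Cc2ccc(OC)cc2)CC1`: > 100000 nM

Compound 3 therefore has no number, only a limit, and it shares (the limit of > 100000 nM in this assay, at which 3 of the 3 values shown sit).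

Compound 4 `CCCNC(=O)C1CCN(C(=O)c2cc3sc(CNC(C)c4ccccc4)cc3n2Cc2ccc(OC)cc2)CC1` carries ((1-phenylethyl)amino)methyl in place of acetyl on an aromatic carbon, next to the ring sulfur: ((1-phenylethyl)amino)methyl in place of acetyl on an aromatic carbon.

Within the data shown here, the only measured step touching this group is a step that the two limits leave unreadable from compound 2 to compound 3, so it offers no size to carry over. Only a small loss of tolerance in this assay is expected, if any, because of the limit of > 100000 nM in this assay, at which 3 of the 3 values shown sit. The expected change is an at least 1.6-fold lower number from compound 3 to compound 4 (0.22 log units; that floor lies within the scatter). For compound 4 the estimated value is 60000 nM, with an expected range of 15000 nM to 100000 nM.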

Compound 4, half-maximal cytotoxic concentration: 33900 nM
For compound 4 the middle estimate is 1.8-fold (0.25 log units) above the measured one; measured number inside the range.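

In this assay, among these compounds, the aromatic carbon next to the ring sulfur is the first place to give a readable change: ((1-phenylethyl)amino)methyl in place of acetyl gives an at least 2.9-fold lower number from compound 3 to compound 4 (0.46 log units; beyond the scatter) and in place of benzoyl gives an at least 2.9-fold lower number from compound 2 to compound 4 (0.46 log units; beyond the scatter) as well. Both sizes are bounds rather than exact steps, and acetyl and benzoyl remain unresolved from each other: the limit of > 100000 nM in this assay, at which 3 of the 4 values shown sit.

Going by these compounds, whether the lower number goes with the 1-phenylethyl part or with the amine nitrogen stays open. An aminomethyl group or a carboxylic acid on this carbon would separate the two.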